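This account rests on a few compounds, and the source may have more. Where it says the series, first, only, none or still open, it means among the compounds named here.

Measured so far in a functional assay on HepG2 cells (Homo sapiens) for antiproliferative activity, read by MTT assay, with a stated time of 72 h; a higher number here means a weaker inhibitor, a lower number a stronger inhibitor:
compound 1, `COc1cc2c(Nc3ccc(C#N)cc3)ncnc2cc1OCCCN1CCC(C)CC1`, gives 32100 nM
compound 2, `COc1cc2c(Nc3ccc(C#N)cc3)ncnc2cc1OCCCN1CCN(C)CC1`, gives 13800 nM
compound 3, `COc1cc2c(Nc3cccc(C#N)c3)ncnc2cc1OCCCN1CCC(C)CC1`, gives 18200 nM

These three compounds share a common core and differ at two places. Compound 1 and compound 3 have the same atoms joined differently: 3-cyanophenyl in place of 4-cyanophenyl on a nitrogen on an aromatic ring. Across that change the numbers in this assay stay within the scatter, a 1.8-fold lower number from compound 1 to compound 3 (0.25 log units; within the scatter), so nothing can be read from it. Compound 1 and compound 2 differ at the other place: 4-methylpiperazin-1-yl in place of 4-methylpiperidin-1-yl on a saturated chain carbon, three bonds along the chain from an oxygen on an aromatic ring. Here the step is a 2.3-fold lower number from compound 1 to compound 2 (0.37 log units; beyond the scatter), a modest move that goes beyond the scatter.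

The unmeasured compound 4, `COc1cc2c(Nc3cccc(C#N)c3)ncnc2cc1OCCCN1CCN(C)CC1`, combines both alterations. It differs from compound 3 in exactly the way compound 2 differs from compound 1: 4-methylpiperazin-1-yl in place of 4-methylpiperidin-1-yl on a saturated chain carbon, three bonds along the chain from an oxygen on an aromatic ring. The place description is the same word for word in both pairs, so this is the same change, seen a second time; it occurs twice among the compounds shown.

Within the data shown here, with only one measured example of this change, the expectation for compound 4 rests on that single step, a 2.3-fold lower number from compound 1 to compound 2 (0.37 log units; beyond the scatter), applied to the value of compound 3, 18200 nM. Compound 4 is therefore expected to show a step of about a 2.1-fold lower number from compound 3 to compound 4 (0.33 log units; beyond the scatter) in this assay, the same direction and roughly the same size as seen from compound 1 to compound 2. Among the measured compounds shown here, the estimate for compound 4 in this assay is 8500 nM, with a plausible range from 4000 nM to 18000 nM, the width reflecting that only one prior instance of the change is available.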

Compound 4, half-maximal inhibitory concentration: 18300 nM
Compound 4: middle estimate off by 2.2-fold (0.33 log units), on the low side; the whole stated range lies below it.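

In this assay, the step from 4-methylpiperidin-1-yl to 4-methylpiperazin-1-yl on the core bearing 3-cyanophenyl is a 1.0-fold higher number from compound 3 to compound 4 (0.00 log units; within the scatter), which lies within the scatter, and the two readings of this change cannot be told apart: the same change on two cores in this assay, a 2.3-fold lower number (0.37 log units; beyond the scatter) from compound 1 to compound 2 and a 1.0-fold higher number (0.00 log units; within the scatter) from compound 3 to compound 4, 2.3-fold (0.37 log units) apart, within the scatter of two such steps

The other change, read on the compounds bearing 4-methylpiperazin-1-yl, is a 1.3-fold higher number from compound 2 to compound 4 (0.12 log units; within the scatter), and it also cannot be told apart from its earlier reading: the same change on two cores in this assay, a 1.8-fold lower number (0.25 log units; within the scatter) from compound 1 to compound 3 and a 1.3-fold higher number (0.12 log units; within the scatter) from compound 2 to compound 4, 2.3-fold (0.37 log units) apart, within the scatter of two such steps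

These four compounds therefore give no firm sign that either change behaves differently from one core to the other, but they do not show that the modest step first seen with the piperazine carries over, since it went beyond the scatter on one core only and each core offers a single pair.

The compounds shown leave open whether a morpholin-4-yl group or an unsubstituted piperidin-1-yl group at the end of the chain would give a clearer step on both cores. They also leave open what a butyl chain in place of the propyl chain, or a chlorine atom in place of the nitrile on the phenyl ring, would do to the numbers.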